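A few compounds are considered here, and "the series" means these few. Any claim that something is new, unique, unknown or untested is made for them only; others in the source may bear on it.

Measured so far in a functional assay on CHO-K1 cells for antagonist activity at adenosine receptor A1 (Homo sapiens), read by a beta-galactosidase reporter and cAMP accumulation, with stated times of 15 min and 6 h; on this read-out higher numbers stand for weaker inhibition and lower numbers for stronger inhibition:
compound 1, `Nc1nc(-c2ncco2)nc2sc(Cc3ccccc3)cc12`, 310 nM;
compound 2, `Nc1nc(-c2cnco2)nc2sc(Cc3ccccc3)cc12`, 106 nM;
compound 3, `N#Cc1cccc(-c2nc(N)c3cc(Cc4ccccc4)sc3n2)c1`, 222 nM.

Compound 3 holds the second highest of the three numbers. Its nearest neighbour is compound 1, with a 1.4-fold lower number from compound 1 to compound 3 (0.15 log units; within the scatter), a gap that stays within the scatter. The furthest is compound 2, with a 2.1-fold higher number from compound 2 to compound 3 (0.32 log units; beyond the scatter), a modest step beyond the scatter. Among the measured compounds shown here, the only other measured step, a 2.9-fold lower number from compound 1 to compound 2 (0.47 log units; beyond the scatter), also lies beyond the scatter.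

Compound 4, `N#Cc1cccc(-c2nc(N)c3cc(Cc4ccccc4F)sc3n2)c1`, differs from compound 3 by one change: fluoro in place of hydrogen on an aromatic carbon. All three measured steps change the group on the other aromatic carbon of the shared core, the oxazolyl or cyanophenyl substituent, and leave the benzyl group untouched. For the measured compounds named here, no measured step therefore speaks to a fluoro in place of hydrogen on the benzyl ring, and the three compounds give no guide to its effect. Without such a guide, compound 4 is expected to stay close to compound 3 in this assay, with no step beyond the scatter. Compound 4 is thus estimated at 200 nM, in a range from 70 nM to 600 nM, which corresponds to an expected step of a 1.1-fold lower number from compound 3 to compound 4 (0.05 log units; within the scatter).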

Compound 4, inhibition constant: < 16 nM
Compound 4: only a limit was reported; the forecaster's own chance of this, stated with the estimate: 3%; at least 12-fold (1.09 log units) between middle value and limit.
By their numbers in this assay, from the lowest: compound 2; then compounds 3 and 1 (each within the scatter of the next). At a limit, below all of these: compound 4.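

In this assay, the change from benzyl to 2-fluorobenzyl gives an at least 13-fold lower number from compound 3 to compound 4 (1.14 log units; beyond the scatter), the largest step shown and larger than any of the steps at the other aromatic carbon of the shared core. Compounds 1, 2 and 3 all carry the same unsubstituted benzyl group, so they could say nothing about this ring; compound 4 shows that a single fluoro, ortho to a large group on that ring, can move the number in this assay further than any exchange of the oxazolyl and cyanophenyl groups shown here. Compound 4 is reported with a limit of the assay rather than a number, so its step gives a bound and not a size: the limit of < 16 nM in this assay, at which 1 of the 4 values shown sits.

On these data alone, whether the same change would carry over to the oxazolyl compounds, compound 1 and compound 2, remains open, since the 2-fluorobenzyl group appears here only with the 3-cyanophenyl group. Also open, as far as these compounds go, is whether this result is specific to fluoro at this place, or whether a chloro, a methyl or a methoxy group there, or a fluoro elsewhere on the same ring, would read the same way.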